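Cytotoxicity notes: chain-end aromatic swap on compound 1

The source may hold more compounds than are shown below. What is called first, only, known or untested is meant among the compounds shown, and "the series" means these compounds.

Measured compounds in an ADME assay on HepG2 cells (Homo sapiens) for cytotoxicity, read by luminescence, CellTiter-Glo and ATP content, with a stated time of 72 h; a higher number here means that more compound is needed for the effect, a lower number that less compound is needed:
- compound 1, `CC(C)Cc1ccc2c(NCCCNCc3ccco3)ccnc2c1`, 16000 nM
- compound 2, `COc1ccc(F)cc1CNCCCNc1ccnc2cc(CC(C)C)ccc12`, 2900 nM
- compound 3, `COc1cccc(CNCCCNc2ccnc3cc(Oc4cccc(N(C)C)c4)ccc23)c1O`, 7300 nM

Compound 1 shows the highest number of the three in this assay; compound 3 is nearest to it and compound 2 furthest, both beyond the scatter. For the measured compounds named here, the only single-place step recorded is a 5.5-fold lower number from compound 1 to compound 2 (0.74 log units; beyond the scatter), which concerns the aromatic group on the saturated chain carbon bound to an amine nitrogen, at the far end of the molecule from the change considered here. Compound 3 differs from compound 1 in several places at once, so its value shows only that it too sits lower than compound 1.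

Compound 4, `c1ccc(CCc2ccc3c(NCCCNCc4ccco4)ccnc3c2)cc1`, is not yet measured. It differs from compound 1 as follows: benzyl in place of isopropyl on a saturated chain carbon bound to an aromatic carbon. Going by the values given here, no measured step touches this part of the core of compound 1, so there is no direct precedent for the size or direction of the change. The one pattern seen so far is that both departures from compound 1 lowered the number, but neither is at this place. The step is therefore expected to be small or modest, a 1.6-fold lower number from compound 1 to compound 4 (0.20 log units; within the scatter), with a direction leaning lower only weakly. For compound 4 the estimate is 10000 nM, with a range from 3500 nM to 28000 nM.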

Compound 4, half-maximal effective concentration: 16000 nM
For compound 4 the middle estimate is 1.6-fold (0.20 log units) below the measured one; the measured number falls inside the stated range.
By their numbers in this assay, from the lowest: compound 2; then compound 3; then compounds 1 and 4 (each within the scatter of the next).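

Benzyl in place of isopropyl on a saturated chain carbon bound to an aromatic carbon gives no change at the digits printed from compound 1 to compound 4 (within the scatter) in this assay and is the first reading at this place on the core of compound 1. The added six-membered aromatic ring therefore leaves the number unmoved here, whereas 5-fluoro-2-methoxyphenyl in place of furan-2-yl on a saturated chain carbon bound to an amine nitrogen gives a 5.5-fold lower number from compound 1 to compound 2 (0.74 log units; beyond the scatter) in the same read-out. No measurement shown accounts for the flat result at this place.

A single step cannot show whether this place stays flat for other groups, such as an amine, a carboxylic acid or a longer chain. From the compounds shown here alone, it is also open whether benzyl behaves the same way when 5-fluoro-2-methoxyphenyl replaces furan-2-yl in the same molecule.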